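The source may hold more compounds than are shown below. What is called first, only, known or untested is meant among the compounds shown, and "the series" means these compounds.

Three compounds share one core and differ in the aryl group attached to it. Compound 1 `CCOC(=O)c1oc2cc(-c3ccc(OC)c(OC)c3)cc(O)c2c1C` carries two methoxy groups on that ring. In a functional assay on VA-13 cells (Homo sapiens) for cytotoxicity (on this read-out higher numbers stand for an effect only at larger amounts of compound and lower numbers for an effect already at smaller amounts), compound 1 reaches only the limit of the assay, > 4 ug/mL. Compound 2 `CCCCOc1ccccc1-c1cc(O)c2c(C)c(C(=O)OCC)oc2c1` carries a butoxy group, and in this assay compound 2 likewise stops at the limit, > 4 ug/mL. Among the compounds with values here, compound 3 `CCOC(=O)c1oc2cc(-c3cccc(C(F)(F)F)c3)cc(O)c2c1C` carries a trifluoromethyl group and is the one compound with a number: in this assay compound 3 gives 0.7 ug/mL. Within the data shown here, compound 3 thus stands at the only measured value among the three, the other two sitting at the limit of > 4 ug/mL in this assay, at which 2 of the 3 values shown sit.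

Compound 4 `CCCCOc1cccc(-c2cc(O)c3c(C)c(C(=O)OCC)oc3c2)c1` has not been measured. It differs from compound 3 in one place: butoxy in place of trifluoromethyl on an aromatic carbon. Among the measured compounds shown here, no measured pair shows this exact change. Both compounds that lack a trifluoromethyl group, compound 1 and compound 2, sit at a limit in this assay. The step expected here is a loss of potency beyond the usual scatter, a 5.7-fold higher number from compound 3 to compound 4 (0.76 log units; beyond the scatter). Compound 4 is therefore expected to give about 4 ug/mL, between 1.2 ug/mL and 12 ug/mL, with a fair chance that only a limit is reported.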

Compound 4, half-maximal effective concentration: 0.85 ug/mL
The estimate for compound 4 lay 4.7-fold (0.67 log units) above the measured number; measured number outside the range, below it.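

At this place, on an aromatic carbon of the six-membered ring and meta to a large group, butoxy stands in for trifluoromethyl with a 1.2-fold higher number from compound 3 to compound 4 (0.08 log units; within the scatter) in this assay, so the two groups cannot be told apart here on this read-out. Before this result, only the compound with trifluoromethyl had a number, and compound 4 now shows that a measured value at this level does not depend on that group, which means that the link suggested by the earlier compounds does not hold. A butoxy group does not by itself go with a limit either, since compound 4 gives a number, whereas compound 2, which also carries butoxy, and compound 1 remain limits of the assay and not numbers: the limit of > 4 ug/mL in this assay, at which 2 of the 4 values shown sit.

The compounds shown leave open whether this place accepts groups of other kinds, such as an amine, a carboxylic acid or a chain longer than butoxy, as readily as it accepts these two. They also leave open how far compound 1 and compound 2 lie from compound 3 and compound 4, since a limit gives no number to compare.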